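Trifluoromethyl to Methoxycarbonyl on the Anilino Ring

The source may hold more compounds than are shown below. What is called first, only, known or untested is meant among the compounds shown, and "the series" means these compounds.

Two compounds of a shared core have numbers in a functional assay on A549 cells (Homo sapiens) for antiproliferative activity, read by MTT assay, with a stated time of 72 h; a lower number here means a stronger inhibitor, a higher number a weaker inhibitor. Compound 1 `COc1ccc(Nc2ncnc3ccc(NC(=O)Nc4ccc(CN5CCN(C)CC5)cc4)cc23)cc1Cl` gives 3570 nM in this assay. For the measured compounds named here, compound 2 `CN1CCN(Cc2ccc(NC(=O)Nc3ccc4ncnc(Nc5cccc(C(F)(F)F)c5)c4c3)cc2)CC1` gives 1650 nM in this assay, the lowest of the two numbers, and the single measured step, a 2.2-fold lower number from compound 1 to compound 2 (0.34 log units; beyond the scatter), is the only comparison available. Compound 3 `COC(=O)c1cccc(Nc2ncnc3ccc(NC(=O)Nc4ccc(CN5CCN(C)CC5)cc4)cc23)c1` is not yet measured in this assay. It differs from compound 2 in one place: methoxycarbonyl in place of trifluoromethyl on an aromatic carbon. Going by the values given here, no measured step touches this exchange; the step from compound 1 to compound 2 concerns a different substitution pattern on the same ring, so it bears on compound 3 only in showing that changes on this ring shift the number by a modest amount. The account therefore expects a modest step in this assay, most likely toward a higher number, though a step within the scatter cannot be excluded; the expected step is a 1.8-fold higher number from compound 2 to compound 3 (0.26 log units; within the scatter). Compound 3 is estimated at 3000 nM in this assay, with a range from 800 nM to 12000 nM.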

Compound 3, half-maximal inhibitory concentration: > 10000 nM
Compound 3: no number, only a limit; the forecaster's own chance of this, stated with the estimate: 10%; at least 3.3-fold (0.52 log units) between middle value and limit.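

In this assay compound 3 gives no number, only a limit of the assay: the limit of > 10000 nM in this assay, at which 1 of the 3 values shown sits. Even so, the exchange of trifluoromethyl for methoxycarbonyl, both of 4 heavy atoms, can be read as a step, an at least 6.0-fold higher number from compound 2 to compound 3 (0.78 log units; beyond the scatter), and this shows that the choice of group on this aromatic carbon can move the number beyond the scatter even when the size of the group, counted in heavy atoms, stays the same. The 3-(methoxycarbonyl)phenyl group also falls on the higher side of the 3-chloro-4-methoxyphenyl group, an at least 2.8-fold higher number from compound 1 to compound 3 (0.44 log units; beyond the scatter), so of the three groups shown on this nitrogen it gives the weakest inhibitor, and the earlier step, a 2.2-fold lower number from compound 1 to compound 2 (0.34 log units; beyond the scatter), gave no sign of this.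

The limit leaves the true size of both new steps open, and the compounds shown cannot tell whether the loss follows from the carbonyl, the methyl of the ester, or the 2 hydrogen-bond acceptors that enter with methoxycarbonyl. On these data alone, it also remains open whether a carboxylic acid, a primary amide or a nitrile on the same aromatic carbon would sit nearer compound 2 or compound 3.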